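The source may hold more compounds than are shown below. What is called first, only, known or untested is meant among the compounds shown, and "the series" means these compounds.

Three compounds built on one shared core were tested in a functional assay on MCF7 cells (Homo sapiens) for cytotoxicity, read by MTT assay, with a stated time of 24 h; on this read-out lower numbers stand for stronger inhibition and higher numbers for weaker inhibition. Compound 1 `Cc1ccc2oc(SCC(=O)Nc3ccc(-c4nc(-c5ccccc5)c(-c5ccccc5)n4C)cc3)nc2c1` gives 22.4 ug/mL, compound 2 `Cc1nnc(SCC(=O)Nc2ccc(-c3nc(-c4ccccc4)c(-c4ccccc4)n3C)cc2)s1` gives 3.2 ug/mL, and compound 3 `CN1CCN(CC(=O)Nc2ccc(-c3nc(-c4ccccc4)c(-c4ccccc4)n3C)cc2)CC1` gives 76.5 ug/mL, the highest number of the three. The steps into compound 3 were a 3.4-fold higher number from compound 1 to compound 3 (0.53 log units; beyond the scatter) and a 24-fold higher number from compound 2 to compound 3 (1.38 log units; beyond the scatter). Compound 4 `COc1ccc(CN2CCN(CC(=O)Nc3ccc(-c4nc(-c5ccccc5)c(-c5ccccc5)n4C)cc3)CC2)cc1` differs from compound 3 by 4-methoxyphenyl in place of hydrogen on a saturated chain carbon bound to an amine nitrogen in a ring. Within the data shown here, none of the measured steps touches this part of the molecule; they all exchange the whole group on the saturated chain carbon bound to the carbonyl carbon, so they give no direct guide here. The expected step is therefore modest, a 1.5-fold lower number from compound 3 to compound 4 (0.18 log units; within the scatter), in this assay. Compound 4 is estimated at 50 ug/mL, with a range from 15 ug/mL to 150 ug/mL.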

Compound 4, half-maximal inhibitory concentration: 80 ug/mL
Estimate against measurement, compound 4: 1.6-fold (0.20 log units) below; the measured number falls inside the stated range.
By their numbers in this assay, from the lowest: compound 2; then compound 1; then compounds 3 and 4 (each within the scatter of the next).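

Putting 4-methoxyphenyl on a saturated chain carbon bound to an amine nitrogen in a ring, which turns methyl into 4-methoxybenzyl, gives a 1.0-fold higher number from compound 3 to compound 4 (0.02 log units; within the scatter), so the two compounds cannot be told apart. The earlier steps shown here exchanged the whole group on the chain carbon bound to the carbonyl carbon, whereas this one shows that 8 more heavy atoms, including an aromatic ring, can be added at this place without a difference beyond the scatter. Nothing measured here accounts for this result. Going by these compounds, whether a carboxylic acid or an amine in place of 4-methoxyphenyl would give a similar number remains open.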